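Sulfone series: amide replacement at the chain carbon

A few compounds are considered here, and "the series" means these few. Any claim that something is new, unique, unknown or untested is made for them only; others in the source may bear on it.

Measured compounds:
compound 1 `COCCNC[C@@H]1CCCc2cc(S(=O)(=O)c3cccc(F)c3)ccc21`: 0.251 nM
compound 2 `N=C(N)NC(=O)C[C@@H]1CCCc2cc(S(=O)(=O)c3cccc(F)c3)ccc21`: 0.631 nM

Going by the values given here, in an assay on isolated protein for displacement of a labelled ligand from 5-hydroxytryptamine receptor 6 (Homo sapiens) (on this read-out higher numbers stand for weaker inhibition and lower numbers for stronger inhibition), compound 2 stands at the higher of the two numbers; the only single-point step measured so far is a 2.5-fold higher number from compound 1 to compound 2 (0.40 log units; beyond the scatter), a modest loss. Compound 3 `CC(C)(C)C(=O)NC[C@@H]1CCCc2cc(S(=O)(=O)c3cccc(F)c3)ccc21` carries a group of 7 heavy atoms (5 carbon, 1 nitrogen, 1 oxygen; no ring) in place of a group of 6 heavy atoms (2 carbon, 3 nitrogen, 1 oxygen; no ring), on a saturated chain carbon bound to a saturated ring carbon. Among the compounds with values here, no measured step covers a change of this kind: the step from compound 1 to compound 2 exchanged one chain group for another at the same carbon, and the group entering compound 3 resembles neither. That step gives no direct guide, only the observation that the shared core tolerates variation at this chain carbon with a modest shift. Given that the change in compound 3 goes further from both measured groups than they do from each other, a weakening beyond the scatter is expected, with wide uncertainty. For compound 3 the expected step is a 6.3-fold higher number from compound 2 to compound 3 (0.80 log units; beyond the scatter), and the estimate is 4 nM (range 0.8 nM to 25 nM).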

Compound 3, inhibition constant: 3.98 nM
Compound 3: the middle estimate sits 1.0-fold (0.00 log units) above what was measured, and the stated range covers the measured number.
By their numbers in this assay, from the lowest: compound 1; then compound 2; then compound 3.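

In this assay, going by these compounds alone, the ((tert-butyl)carbonyl)amino group gives a 6.3-fold higher number from compound 2 to compound 3 (0.80 log units; beyond the scatter) and also a 16-fold higher number from compound 1 to compound 3 (1.20 log units; beyond the scatter) as the first large step, so this chain carbon is less forgiving than the earlier exchange suggested. The second of these steps keeps the amine nitrogen and replaces only 2-methoxyethyl with (tert-butyl)carbonyl, which ties the loss to the group carried on that nitrogen. No measurement at hand accounts for the loss.

On these data alone, whether the change follows the carbonyl or the tert-butyl stays open; an acetyl group and a 2,2-dimethylpropyl chain on the same nitrogen would separate the two. Also open is how a carboxylic acid or a primary amine at this chain carbon would compare with the groups shown.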